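Trimming the aryl group on the oxadiazole of compound 1

The source may hold more compounds than are shown below. What is called first, only, known or untested is meant among the compounds shown, and "the series" means these compounds.

Compound 1 `Cc1nc2cc(OC[C@H](O)CN3CCN(Cc4noc(-c5ccc(C(C)(C)C)cc5)n4)CC3)ccc2s1` has the lowest number of the three measured compounds in a functional assay on mitochondria from heart for inhibition of peroxisomal acyl-coenzyme A oxidase 1 (Rattus norvegicus) (a higher number here means a weaker inhibitor, a lower number a stronger inhibitor), where compound 1 gives 180 nM. Compound 3 `Cc1nc2cc(OC[C@H](O)CN3CCN(Cc4nc(-c5ccc(C(F)(F)F)cc5)sc4C)CC3)ccc2s1` gives 1500 nM in this assay, and compound 2 `Cc1nc2cc(OC[C@H](O)CN3CCN(Cc4coc(-c5ccc(C(F)(F)F)cc5)n4)CC3)ccc2s1` gives 11000 nM; both lie beyond the scatter from compound 1. Compound 4 `Cc1cccc(-c2nc(CN3CCN(C[C@@H](O)COc4ccc5sc(C)nc5c4)CC3)no2)c1` has not been measured. It differs from compound 1 in one place: 3-methylphenyl in place of 4-(tert-butyl)phenyl on an aromatic carbon. Among the measured compounds shown here, no measured pair shows this change directly. The step from compound 1 to compound 4 is expected to go toward a higher number, somewhat beyond the scatter, a 5.0-fold higher number from compound 1 to compound 4 (0.70 log units; beyond the scatter). Compound 4 is therefore estimated at 900 nM in this assay, within a range from 250 nM to 3500 nM.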

Compound 4, half-maximal inhibitory concentration: 6500 nM
The estimate for compound 4 lay 7.2-fold (0.86 log units) below the measured number, and the stated range ends below it.
By their numbers in this assay, from the lowest: compound 1; then compound 3; then compounds 4 and 2 (each within the scatter of the next).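

In this assay, 3-methylphenyl in place of 4-(tert-butyl)phenyl on the five-membered aromatic ring gives a 36-fold higher number from compound 1 to compound 4 (1.56 log units; beyond the scatter), so this aryl group cannot be trimmed in this way without a large rise in the number. Both groups have one six-membered aromatic ring of carbon only, and the entering group has fewer heavy atoms than the group it replaces. Nothing available accounts for the size of this step. As far as these compounds go, compound 4 alters both the substituent and its place on the phenyl ring, so their separate contributions remain open. From the compounds shown here alone, how a plain phenyl group would stand here is also open.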